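The compounds below may be only part of what the source reports. "The series", "measured", "known", "first", "only" and "open" are said of these compounds alone.

Of the compounds shown here, three of one series have been measured in a functional assay on HeLa cells (Homo sapiens) for inhibition, read by MTT assay, with a stated time of 72 h; a lower number here means a stronger inhibitor, a higher number a weaker inhibitor. Compound 1 `CN(C(=O)NC(=O)c1ccc(F)c(F)c1)c1nc(C(F)(F)F)c(C(=O)N/N=C/c2ccc(C(F)(F)F)cc2)s1` gives 5.1 ug/mL. Among the compounds with values here, compound 2 `CN(C(=O)NC(=O)c1cccc(C(F)(F)F)c1)c1nc(C(F)(F)F)c(C(=O)N/N=C/c2ccc(C(F)(F)F)cc2)s1` gives 7.35 ug/mL; the only single-point step among the measured compounds, a 1.4-fold higher number from compound 1 to compound 2 (0.16 log units; within the scatter), lies between these two. Compound 3 `CN(C(=O)NC(=O)c1c(F)cccc1F)c1nc(C(F)(F)F)c(C(=O)N/N=C/c2cccc(C(F)(F)F)c2)s1` gives 21.6 ug/mL, the highest of the three numbers, beyond the scatter from both compound 1 and compound 2.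

Compound 4 `CN(C(=O)NC(=O)c1c(F)cccc1F)c1nc(C(F)(F)F)c(C(=O)N/N=C/c2ccc(C(F)(F)F)cc2)s1` has not yet been measured. It differs from compound 3 in one place: 4-(trifluoromethyl)phenyl in place of 3-(trifluoromethyl)phenyl on a carbon with a double bond to nitrogen. Within the data shown here, no measured step touches this position; the step from compound 1 to compound 2 concerns the other end of the molecule and is within the scatter, so it says nothing about this change. What remains is that compound 1 and compound 2, which both carry the 4-(trifluoromethyl)phenyl group, sit well under compound 3. On that basis a modest decrease, a 2.0-fold lower number from compound 3 to compound 4 (0.29 log units; within the scatter), is expected, with wide uncertainty. Compound 4 is estimated at 11 ug/mL, in the range 4 ug/mL to 30 ug/mL.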

Compound 4, half-maximal inhibitory concentration: 30.6 ug/mL
Compound 4: middle estimate off by 2.8-fold (0.44 log units), on the low side; measured number outside the range, above it.
By their numbers in this assay, from the lowest: compounds 1 and 2 (each within the scatter of the next); then compounds 3 and 4 (each within the scatter of the next).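

Moving the trifluoromethyl group, with 4-(trifluoromethyl)phenyl in place of 3-(trifluoromethyl)phenyl on a carbon with a double bond to nitrogen, gives a 1.4-fold higher number from compound 3 to compound 4 (0.15 log units; within the scatter) in this assay, so these two groups cannot be told apart here when 2,6-difluorophenyl sits on the carbonyl carbon. The large differences among these compounds lie instead at the carbonyl end, where 2,6-difluorophenyl in place of 3-(trifluoromethyl)phenyl gives a 4.2-fold higher number from compound 2 to compound 4 (0.62 log units; beyond the scatter) and 2,6-difluorophenyl in place of 3,4-difluorophenyl gives a 6.0-fold higher number from compound 1 to compound 4 (0.78 log units; beyond the scatter), although each of these is a single comparison. Nothing available bears on the reason for these steps.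

As far as these compounds go, whether the two trifluoromethylphenyl groups also match when 3,4-difluorophenyl sits on the carbonyl carbon remains open. So does the effect of an amine or a carboxylic acid in place of the trifluoromethyl group.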